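Urea series on myeloma cell growth: notes toward compound 4

A few compounds are considered here, and "the series" means these few. Any claim that something is new, unique, unknown or untested is made for them only; others in the source may bear on it.

Measured so far in a functional assay on RPMI-8226 cells (Homo sapiens) for inhibition, read by sulforhodamine B assay, with a stated time of 48 h, tested at 100 uM; a lower number here means a stronger effect, a higher number a weaker effect of the compound at the concentration tested:
compound 1 `COc1cc(Cl)cc(-c2nn(-c3cccc(NC(=O)Nc4ccc(Cl)c(C(F)(F)F)c4)c3)cc2-c2ccncc2)c1` gives -32%;
compound 2 `COc1cc(Cl)cc(-c2nn(-c3cccc(NC(=O)Nc4cc(C(F)(F)F)cc(C(F)(F)F)c4)c3)cc2-c2ccncc2)c1` gives -8%;
compound 3 `COc1cc(Cl)cc(-c2nn(-c3cccc(NC(=O)Nc4ccc(Cl)c(Cl)c4)c3)cc2-c2ccncc2)c1` gives -34%.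

Compound 3 holds the lowest of the three numbers in this assay. Compound 1 sits nearest, within the scatter, so no order between compound 3 and compound 1 can be read; compound 2 lies clearly beyond it. Among the compounds with values here, the one step that bears on the present change is a number 2 percentage points lower from compound 1 to compound 3 (within the scatter). Compound 4 `COc1cc(Cl)cc(-c2nn(-c3cccc(NC(=O)Nc4cccc(C(F)(F)F)c4)c3)cc2-c2ccncc2)c1` differs from compound 3 by 3-(trifluoromethyl)phenyl in place of 3,4-dichlorophenyl on an amide-type nitrogen. Within the data shown here, no measured step removes a ring substituent in this way, and compound 2 shows that a different substitution of the entering ring can raise the number markedly. A moderate upward step is expected: a number 16 percentage points higher from compound 3 to compound 4 (beyond the scatter). Compound 4 is therefore estimated at -18%, within -40% to 5%.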

Compound 4, a percentage reported as activity, at one concentration (the size of the read-out at that concentration, not a potency): -43%
Beside the measured number, compound 4's estimate is 25 percentage points above it; the whole stated range lies above it.
By their numbers in this assay, from the lowest: compounds 4, 3 and 1 (each within the scatter of the next, the first and the last beyond it); then compound 2.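

In this assay the swap on the amide-type nitrogen gives a number 9 percentage points lower from compound 3 to compound 4 (within the scatter) and so separates 3-(trifluoromethyl)phenyl from 3,4-dichlorophenyl by nothing readable. A second substituent on this ring is not required to keep the number low: hydrogen in place of trifluoromethyl gives a number 35 percentage points lower from compound 2 to compound 4 (beyond the scatter) and hydrogen in place of chloro gives a number 11 percentage points lower from compound 1 to compound 4 (beyond the scatter) in the two single-place removals. Nothing on hand accounts for these steps.

Still open, on these data alone, is whether plain phenyl holds the number this low. Also open, as far as these compounds go, is how an amine or a carboxylic acid on this ring would read.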